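Moving the phenyl ring in a fluorinated hydroxamic acid series

A few compounds are considered here, and "the series" means these few. Any claim that something is new, unique, unknown or untested is made for them only; others in the source may bear on it.

Compound 1 `O=C(NO)C(F)(F)C(F)(F)C(F)(F)C(F)(F)C(F)(F)C(F)(F)C(=O)Nc1ccc(I)cc1` is the reference point. Among the measured compounds shown here, in an assay on isolated protein for inhibition of histone deacetylase 7 (Homo sapiens), read by fluorescence (on this read-out lower numbers stand for tighter binding and higher numbers for weaker binding), compound 1 gives 4100 nM, the lowest of the three numbers measured so far. Compound 2 `O=C(NO)C(F)(F)C(F)(F)C(F)(F)C(F)(F)C(F)(F)C(F)(F)C(=O)Nc1ccc(-c2cn(-c3ccccc3)nn2)cc1` gives 30000 nM and compound 3 `O=C(NO)C(F)(F)C(F)(F)C(F)(F)C(F)(F)C(F)(F)C(F)(F)C(=O)Nc1cccc(-c2ccccc2)c1` gives 14000 nM, so both changes away from compound 1 weakened binding: a 7.3-fold higher number from compound 1 to compound 2 (0.86 log units; beyond the scatter) and a 3.4-fold higher number from compound 1 to compound 3 (0.53 log units; beyond the scatter).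

Compound 4 `O=C(NO)C(F)(F)C(F)(F)C(F)(F)C(F)(F)C(F)(F)C(F)(F)C(=O)Nc1ccccc1-c1ccccc1` has not yet been measured. It differs from compound 1 in one place: 2-phenylphenyl in place of 4-iodophenyl on an amide-type nitrogen. For the measured compounds named here, the step most closely related is the one to compound 3, where a phenyl ring also replaced the iodine on the same part of the molecule, only at a different position on the ring, and the number rose by a modest amount. The step to compound 2, where a larger ring system entered, rose further. Going by the values given here, the change to compound 4 is therefore expected to weaken binding by a modest step, a 3.2-fold higher number from compound 1 to compound 4 (0.50 log units; beyond the scatter), with the size uncertain because only a single phenylphenyl example, compound 3 at 14000 nM, is available. For compound 4 the estimate in this assay is 13000 nM, with a range from 4000 nM to 45000 nM.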

Compound 4, dissociation constant: 14000 nM
For compound 4 the middle estimate is 1.1-fold (0.03 log units) below the measured one; measured number inside the range.
By their numbers in this assay, from the lowest: compound 1; then compounds 3 and 4 (each within the scatter of the next); then compound 2.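

In this assay, putting 2-phenylphenyl in place of 4-iodophenyl on the amide-type nitrogen gives a 3.4-fold higher number from compound 1 to compound 4 (0.53 log units; beyond the scatter), so this second phenylphenyl example also binds more weakly than the iodo reference. The comparison between the two phenylphenyl groups gives no change at the digits printed from compound 3 to compound 4 (within the scatter), which means that moving the phenyl ring between these two places on the ring does not separate them in this assay. Nothing available explains either result, so the data describe the trend without giving its cause.

Still open, going by these compounds, is how 4-phenylphenyl would behave, since it would place a phenyl ring where compound 1 carries its iodine. A plain phenyl group, or 2-iodophenyl and 3-iodophenyl, would also help show whether the loss follows from removing the iodine or from adding the phenyl ring.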